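This account rests on a few compounds, and the source may have more. Where it says the series, first, only, none or still open, it means among the compounds named here.

In a functional assay on cells for antagonist activity at C-C chemokine receptor type 4 (Homo sapiens), read by fluorescence and calcium flux, with stated times of 2.5 s and 45 s (on this read-out higher numbers stand for weaker inhibition and lower numbers for stronger inhibition), three compounds have been measured. Compound 2 `Cc1nn([C@H](C)c2ccc(Cl)cc2Cl)c2nc(N3CC[C@H](N4CCCCCC4)[C@H](C)C3)cnc12` gives 23 nM, the lowest of the three numbers. Compound 3 `Cc1nn(C(C)c2ccc(Cl)cc2Cl)c2nc(N3CCC(N4CCCCC4)C(C)C3)cnc12` gives 126 nM and stands nearest to it, yet its gap to compound 2 is beyond the scatter. Compound 1 `C[C@@H]1CC(c2cnc3c(C#N)nn([C@H](C)c4ccc(Cl)cc4Cl)c3n2)=CC[C@@H]1N1CCC[C@H]1C(C)(C)O` gives 384 nM and stands furthest away, again beyond the scatter. On these numbers compound 2 is the strongest inhibitor of the three.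

Compound 4 `Cc1nn([C@H](C)c2ccc(Cl)cc2Cl)c2nc(N3CC[C@H](N4CCC[C@H]4CO)[C@H](C)C3)cnc12` has not yet been measured. It differs from compound 2 in one place: 2-(hydroxymethyl)pyrrolidin-1-yl in place of azepan-1-yl on a saturated ring carbon. The shared core and the six-membered non-aromatic ring with its methyl group are kept; only the group on that saturated ring carbon changes.

Among the measured compounds shown here, no measured pair shows this exact change, so any expectation rests on the spread of the three numbers. For the measured compounds named here, compound 1, the one compound carrying a hydroxyl-bearing group on a five-membered ring, gives 384 nM, but its core differs in more than one place, so it offers no clean step. The step from compound 2 to compound 4 is expected to be a moderate loss of inhibition, a 2.6-fold higher number from compound 2 to compound 4 (0.42 log units; beyond the scatter), possibly within the scatter at its lower end. Compound 4 is thus estimated at 60 nM, in a range from 15 nM to 250 nM.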

Compound 4, half-maximal inhibitory concentration: 32 nM
Compound 4: middle estimate off by 1.9-fold (0.27 log units), on the high side; the range from low to high includes it.
By their numbers in this assay, from the lowest: compounds 2 and 4 (each within the scatter of the next); then compound 3; then compound 1.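

In this assay, putting 2-(hydroxymethyl)pyrrolidin-1-yl in place of azepan-1-yl on the saturated ring carbon gives a 1.4-fold higher number from compound 2 to compound 4 (0.14 log units; within the scatter), the only step shown between compounds that differ in one place; the earlier compounds offered no such direct reading at this position. It shows that, with the shared core and the methyl-bearing six-membered ring kept, this read-out does not separate the two groups, even though one is a seven-membered ring with no hydrogen-bond donor and the other a five-membered ring with a hydrogen-bond donor and a defined stereocentre. The position therefore tolerates this change of ring size and the added hydroxymethyl in this single pair, although no measurement at hand explains that result.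

The compounds shown leave open whether the ring size and the hydroxyl each matter on their own, as would be tested by a plain pyrrolidin-1-yl or by the opposite configuration at the stereocentre of the hydroxymethyl group. From the compounds shown here alone, how a morpholin-4-yl group, or a carboxylic acid in place of the hydroxymethyl, would read at this position also remains open.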